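Swapping a Pentyl Chain for a Sulfonylpiperidine

The source may report more compounds than this note shows. Statements on the series, on what has been measured and on what is new or still open speak of the compounds shown alone.

Measured so far:
Compound 1 `Cc1ccccc1-c1nn(-c2ccc(F)cc2F)cc1CNCCN1CCN(C)CC1`: in an ADME assay on Huh-7 cells (Homo sapiens) for cytotoxicity (a lower number here means that less compound is tolerated, a higher number that more compound is tolerated), compound 1 gives > 20000 nM, which is a limit of the assay rather than a number.
Compound 2 `CCCCCNCc1cn(-c2ccc(F)cc2F)nc1-c1ccccc1C`: in this assay compound 2 gives 17000 nM.

Among the measured compounds shown here, compound 2 thus holds the only plain number in this assay; the other entry is a limit. For the measured compounds named here, the single measured step, an at least 1.1-fold lower number from compound 1 to compound 2 (0.07 log units; that floor lies within the scatter), lies within the scatter, and the limit of > 20000 nM in this assay, at which 1 of the 2 values shown sits, means its true size cannot be pinned down from the data.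

Compound 3 `Cc1ccccc1-c1nn(-c2ccc(F)cc2F)cc1CNC1CCN(S(C)(=O)=O)CC1` differs from compound 2 by 1-(methylsulfonyl)piperidin-4-yl in place of pentyl on an amine nitrogen. The measured step concerns a different part of the molecule, the chain carbon two bonds from the amine nitrogen, and it moved the number hardly at all. Nothing measured here speaks for a shift in either direction once the pentyl chain on the amine nitrogen gives way to the sulfonylpiperidine.

The expectation for compound 3 in this assay is therefore no change beyond the scatter, and a sizeable chance that only a limit is returned. Compound 3 is estimated at 20000 nM, between 8000 nM and 45000 nM. That estimate amounts to a 1.2-fold higher number from compound 2 to compound 3 (0.07 log units; within the scatter).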

Compound 3, half-maximal cytotoxic concentration: > 20000 nM
Compound 3 gave a limit, no number; the forecaster's own chance of this, stated with the estimate: 50%; the middle value lies on the limit itself.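

Among the compounds shown here, on the amine nitrogen, the 5 heavy atoms of the open pentyl chain can give way to the 10 heavy atoms of 1-(methylsulfonyl)piperidin-4-yl, with its six-membered non-aromatic ring and 2 hydrogen-bond acceptors, with no sign of less compound being tolerated in this assay: the change gives an at least 1.1-fold higher number from compound 2 to compound 3 (0.07 log units; that floor lies within the scatter). Compared with compound 2, compound 3 therefore shows that this position tolerates a ring-bearing group as well as a straight chain, although the true size of the step remains unknown. The comparison of compound 1 with compound 3 cannot be read because both entries are limits, which leaves the two amine substituents unranked: the limit of > 20000 nM in this assay, at which 2 of the 3 values shown sit.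

For the compounds shown here, compound 2 remains the only compound with a plain number in this assay, at 17000 nM, so it is unclear whether any substituent on this amine nitrogen would lower that number by more than the scatter. A free piperidine, an acetyl group in place of the methylsulfonyl, or a longer chain such as octyl could each test this, and the compounds shown give no reading for any of them.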